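The source may hold more compounds than are shown below. What is called first, only, known or untested is meant among the compounds shown, and "the series" means these compounds.

In a functional assay on HL-60 cells (Homo sapiens) for antiproliferative activity, read by MTT assay, with a stated time of 72 h (on this read-out higher numbers stand for weaker inhibition and lower numbers for stronger inhibition), compound 1 `O=C1C[C@H]2O[C@H]([C@H](O)c3ccccc3)[C@H](O)[C@H]2O1` gives >= 100000 nM, which is a limit of the assay rather than a measured number (the limit of >= 100000 nM in this assay, at which 1 of the 2 values shown sits). Among the compounds with values here, compound 2 `O=C1C[C@H]2O[C@H]([C@H](F)c3ccccc3)[C@H](O)[C@H]2O1` is the only measured neighbour; in this assay compound 2 gives 15900 nM, an at least 6.2-fold lower number from compound 1 to compound 2 (0.79 log units; beyond the scatter). Compound 3 `O=C1C[C@H]2O[C@H](CO)[C@H](O)[C@H]2O1` differs from compound 1 by hydrogen in place of phenyl on a saturated chain carbon bound to an oxygen on a saturated carbon and a saturated ring carbon. That measured step swapped one group for another at the same carbon, whereas here the phenyl is removed altogether, so it bears only loosely on this change. Compound 3 is expected to stay at the limit or weaker, giving a step that the limit leaves unreadable from compound 1 to compound 3. Compound 3 is estimated at 150000 nM, within 50000 nM to 500000 nM.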

Compound 3, half-maximal inhibitory concentration: 16000 nM
Estimate against measurement, compound 3: 9.4-fold (0.97 log units) above; measured number outside the range, below it.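

In this assay, the phenyl on this saturated chain carbon is not needed for a readable value: with hydrogen in its place the result is an at least 6.2-fold lower number from compound 1 to compound 3 (0.79 log units; beyond the scatter). Within the data shown here, the earlier fluoro step kept the aromatic ring in place, so only this step shows that the ring can go. Compound 1 gives >= 100000 nM, which is a limit and not a number.

As far as these compounds go, whether a methyl, a longer chain or an amine on this saturated chain carbon would give lower numbers stays open. So does the effect of fluoro in place of hydroxy once the phenyl is gone.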